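A few compounds are considered here, and "the series" means these few. Any claim that something is new, unique, unknown or untested is made for them only; others in the source may bear on it.

Series notes. Compound 1 `COc1ccc(S(=O)(=O)Nc2ccc3oc(-c4ccc(NC(=O)c5ccc(Cl)s5)cc4)nc3c2)cc1` has been tested in an assay on isolated protein for inhibition of thiosulfate sulfurtransferase (Homo sapiens); on this read-out higher numbers stand for weaker inhibition and lower numbers for stronger inhibition. In this assay compound 1 gives only a limit, > 100000 nM, and no number. Compound 2 `Nc1ccc(S(=O)(=O)Nc2ccc(-c3nc4cc(NS(=O)(=O)c5ccc(N)cc5)ccc4o3)cc2)cc1` likewise gives only a limit in this assay, > 100000 nM. On the numbers shown, compound 1 therefore stands at the limit of > 100000 nM in this assay, at which 2 of the 2 values shown sit, and nothing measured places it anywhere else. Compound 3 `COc1ccc(S(=O)(=O)Nc2ccc3oc(-c4ccc(NC(=O)c5cccc(C)c5[N+](=O)[O-])cc4)nc3c2)cc1` differs from compound 1 in one place: 3-methyl-2-nitrophenyl in place of 5-chlorothiophen-2-yl on a carbonyl carbon. Within the data shown here, no step between two measured compounds is available for this series, and the two values shown for compound 1 and compound 2 do not separate them in this assay. The step expected here is a number no higher from compound 1 to compound 3 (the limit leaves the size open), that is, none beyond the usual scatter, because both values shown sit at the limit of > 100000 nM in this assay, at which 2 of the 2 values shown sit. Compound 3 is estimated at 100000 nM, between 30000 nM and 300000 nM, with the outcome most likely again reported as a limit rather than a number.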

Compound 3, half-maximal inhibitory concentration: > 100000 nM
Compound 3 gave a limit, no number; the forecaster's own chance of this, stated with the estimate: 80%; the middle value sits exactly at the limit.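

In this assay compound 3 gives > 100000 nM, a limit and not a number. Among these compounds, with compound 1 also reported only as a limit, no step between compound 1 and compound 3 can be read. The compounds shown leave open whether any member of this series gives a number in this assay.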